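This account rests on a few compounds, and the source may have more. Where it says the series, first, only, none or still open, it means among the compounds named here.

The compounds measured so far, with their numbers in an assay on HeLa cells for displacement of a labelled ligand from adenosine receptor A3 (Homo sapiens), read by fluorescence polarization, with a stated time of 30 min; a higher number here means a weaker inhibitor, a lower number a stronger inhibitor:
compound 1 `COc1ccc(-c2cc(NC(=O)COCC(=O)NCC(=O)NC3CCCCC3)nc(-c3ccc(OC)cc3)n2)cc1` gives 14000 nM;
compound 2 `COc1ccc(-c2cc(NC(=O)COCC(=O)NCC(=O)NCc3ccccc3)nc(-c3ccc(OC)cc3)n2)cc1` gives 64600 nM.

Going by the values given here, compound 2 has the higher of the two numbers and is thus the weaker inhibitor of the pair; its only neighbour is compound 1, and the step of a 4.6-fold higher number from compound 1 to compound 2 (0.66 log units; beyond the scatter) separates them, a change of benzyl in place of cyclohexyl on an amide-type nitrogen. Compound 3 `COc1ccc(-c2cc(NC(=O)COCC(=O)N(C)CC(=O)NCc3ccccc3)nc(-c3ccc(OC)cc3)n2)cc1` keeps the benzyl and differs from compound 2 in one place: methyl in place of hydrogen on an amide-type nitrogen. Among the compounds with values here, no measured step bears on this kind of change; the only step known concerns a different group altogether. With nothing to set a direction, the expected step of a 1.2-fold higher number from compound 2 to compound 3 (0.09 log units; within the scatter) is none beyond the scatter, and since compound 2 already sits at a high number, the measurement may come back only as a limit. Compound 3 is therefore estimated at 80000 nM in this assay, within a range of 25000 nM to 250000 nM.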

Compound 3, inhibition constant: 19000 nM
For compound 3 the middle estimate is 4.2-fold (0.62 log units) above the measured one; measured number below the stated range.
By their numbers in this assay, from the lowest: compounds 1 and 3 (each within the scatter of the next); then compound 2.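

In this assay, a 3.4-fold lower number from compound 2 to compound 3 (0.53 log units; beyond the scatter) shows that this amide-type nitrogen is a position where a small change registers: a single methyl moves the number beyond the scatter, towards a stronger inhibitor. Going by these compounds alone, the earlier step concerned only the group at the far amide, so this is the first sign that the nitrogen in the chain matters as well, and in this pair, giving up the amide hydrogen does not weaken the compound. Nothing available explains why the methyl gives this gain.

From the compounds shown here alone, it remains open whether a larger group on this nitrogen, such as ethyl or a longer chain, would lower the number further or raise it again. Going by these compounds, it is also open whether the same methyl would give a similar step with cyclohexyl in place of benzyl.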